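From compound 2 to compound 3: one methyl removed

The source may report more compounds than this note shows. Statements on the series, on what has been measured and on what is new or still open speak of the compounds shown alone.

- compound 1 `Cc1c(CN(C)C)c2ccccc2n1Cc1ccc(C(=O)NO)cc1` gives > 5000 nM (a limit of the assay)
- compound 2 `Cc1c(CN(C)C)c2ccccc2n1S(=O)(=O)c1cccc(/C=C/C(=O)NO)c1` gives 1920 nM

Going by the values given here, in a functional assay on A549 cells (Homo sapiens) for antiproliferative activity, read by sulforhodamine B assay, with a stated time of 48 h (a lower number here means a stronger inhibitor of growth, a higher number a weaker inhibitor of growth), compound 2 gives 1920 nM, the only actual number in this small set. Compound 3 `CN(C)Cc1cn(S(=O)(=O)c2cccc(/C=C/C(=O)NO)c2)c2ccccc12` carries hydrogen in place of methyl on an aromatic carbon. Among the compounds with values here, no measured pair shows this change, so a step no larger than the scatter is expected in this assay, with no firm direction. The expected size is given by a 1.3-fold lower number from compound 2 to compound 3 (0.11 log units; within the scatter). For compound 3 the estimated value is 1500 nM. The expected range for compound 3 runs from 500 nM to 5000 nM.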

Compound 3, concentration for 50% growth inhibition: 1870 nM
Beside the measured number, compound 3's estimate is 1.2-fold (0.10 log units) below it; the range from low to high includes it.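

In this assay, going by these compounds alone, hydrogen in place of methyl on an aromatic carbon of the five-membered aromatic ring gives a 1.0-fold lower number from compound 2 to compound 3 (0.01 log units; within the scatter), the first step that can be read. At this place, next to the ring nitrogen, the methyl can therefore be lost with no readable effect on growth inhibition, and compound 2 and compound 3 cannot be ranked. From the compounds shown here alone, whether an ethyl, a phenyl or a carboxylic acid here would shift the value stays open. Room for reading a weaker compound is limited: the limit of > 5000 nM in this assay, at which 1 of the 3 values shown sits.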